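The source may report more compounds than this note shows. Statements on the series, on what has been measured and on what is new or still open speak of the compounds shown alone.

The measured compounds:

Compound 1, `COc1ccc(C2=NN(C(=O)c3ccc(C)nc3Cl)C(c3ccc(OCc4ccccc4)cc3)C2)cc1`, gives 10500 nM in a functional assay on WM 266-4 cells (Homo sapiens) for antiproliferative activity, read by MTT assay, with a stated time of 24 h; a higher number here means a weaker inhibitor of growth, a lower number a stronger inhibitor of growth.
Compound 2, `O=C(c1cncc(Br)c1)N1N=C(c2ccc(Cl)cc2)CC1c1ccc(OCc2ccccc2)cc1`, gives 8130 nM in this assay.
Compound 3, `O=C(c1ccc(Cl)nc1)N1N=C(c2ccc(Cl)cc2)CC1c1ccc(OCc2ccccc2)cc1`, gives 13200 nM in this assay.

Compound 3 holds the highest of the three numbers, but its distances to compound 1 and to compound 2 both fall within the scatter, so the three compounds cannot be told apart on these values. Going by the values given here, the only single-point step among them, a 1.6-fold higher number from compound 2 to compound 3 (0.21 log units; within the scatter), also stays within the scatter: exchanging one substituted pyridine for another on the carbonyl carbon left the number essentially unchanged.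

Compound 4, `Cc1ccc(C(=O)N2N=C(c3ccc(Cl)cc3)CC2c2ccc(OCc3ccccc3)cc2)c(Cl)n1`, differs from compound 3 in one place: 2-chloro-6-methylpyridin-3-yl in place of 6-chloropyridin-3-yl on a carbonyl carbon. Compound 1 carries the same 2-chloro-6-methylpyridin-3-yl group on its carbonyl carbon, though it differs from compound 4 elsewhere as well, and its value and that of compound 3 lie within the scatter of each other. Nothing in the measured steps points to a shift beyond the scatter, so for compound 4 the expected step is a 1.3-fold lower number from compound 3 to compound 4 (0.10 log units; within the scatter), and compound 4 is estimated at 10500 nM, with a range from 4000 nM to 26000 nM.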

Compound 4, concentration for 50% growth inhibition: 11400 nM
Beside the measured number, compound 4's estimate is 1.1-fold (0.04 log units) below it; the range from low to high includes it.
By their numbers in this assay, from the lowest: compounds 2, 1, 4 and 3 (each within the scatter of the next).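

In this assay, a third substituted pyridine on this carbonyl carbon, with an added methyl group, still cannot be told apart from the other two: 2-chloro-6-methylpyridin-3-yl in place of 6-chloropyridin-3-yl gives a step within the scatter (a 1.2-fold lower number from compound 3 to compound 4 (0.06 log units; within the scatter)), and so does the same group in place of 5-bromopyridin-3-yl (a 1.4-fold higher number from compound 2 to compound 4 (0.15 log units; within the scatter)). Compound 4 also opens a second place to read, an aromatic carbon where chloro in place of methoxy likewise stays within the scatter (a 1.1-fold higher number from compound 1 to compound 4 (0.04 log units; within the scatter)). No measurement at hand explains these results.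

Every group shown on the carbonyl carbon is a halogen-bearing pyridine, so whether an aminopyridine or a benzoic acid there would separate from them remains open. On these data alone, at the aromatic carbon, the effect of an amine or a longer alkoxy chain is equally open.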